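The source may hold more compounds than are shown below. What is called first, only, known or untested is meant among the compounds shown, and "the series" means these compounds.

Measured so far in an assay on isolated protein for binding affinity to adenosine receptor A1 (Homo sapiens); a lower number here means a stronger inhibitor, a higher number a weaker inhibitor:

compound 1, `CC1C(=O)c2nc(CCCCN3N=C(Cl)CCC3=O)[nH]c2N(C)C1=O`: 370 nM
compound 2, `CC1C(=O)c2nc(CCCCN3N=C(c4ccccc4)CCC3=O)[nH]c2N(C)C1=O`: 2120 nM
compound 3, `CCCC1C(=O)c2nc(CN3N=C(Cl)CCC3=O)[nH]c2N(C)C1=O`: 9200 nM

Compound 1 and compound 2 share one core and differ only by phenyl in place of chloro on a carbon with a double bond to nitrogen; this change produced a 5.7-fold higher number from compound 1 to compound 2 (0.76 log units; beyond the scatter), a weakening that lies beyond the usual scatter. Compound 3 is built on a different core; how the two cores differ is not broken down here. Among the three numbers, the value of compound 3 is the highest, and against compound 1 and compound 2 the figures show only that gap, with no single-point comparison available.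

Compound 4, `CCCC1C(=O)c2nc(CN3N=C(c4ccccc4)CCC3=O)[nH]c2N(C)C1=O`, has not yet been measured. It differs from compound 3 by phenyl in place of chloro on a carbon with a double bond to nitrogen. The place of this change is the same, word for word, as the place of the change from compound 1 to compound 2, so it is taken as the same change made on the second core.

For the measured compounds named here, with one earlier step as the only guide, a step of about a 4.9-fold higher number from compound 3 to compound 4 (0.69 log units; beyond the scatter) is expected in this assay, resting on a 5.7-fold higher number from compound 1 to compound 2 (0.76 log units; beyond the scatter). Compound 4 is therefore estimated at 45000 nM, expected between 15000 nM and 130000 nM.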

Compound 4, inhibition constant: 2270 nM
Compound 4: the middle estimate sits 20-fold (1.30 log units) above what was measured, outside the stated range (below it).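

In this assay, phenyl in place of chloro gives a 4.1-fold lower number from compound 3 to compound 4 (0.61 log units; beyond the scatter), so the change does not carry from one core to the other, in direction or in size: the same change on two cores in this assay, a 5.7-fold higher number (0.76 log units; beyond the scatter) from compound 1 to compound 2 and a 4.1-fold lower number (0.61 log units; beyond the scatter) from compound 3 to compound 4, 23-fold (1.37 log units) apart, beyond the scatter of two such steps In this series, then, a step read on the core of compound 1 cannot simply be transferred to the core of compound 3, and the outcome of this change has to be read on each core separately. The two pairs do not show which part of the cores goes with the reversal, and they give no rule for predicting the step on any further core.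

Open, going by these compounds, is whether other groups on the same carbon, such as a methoxy group, an amine or a cyclohexyl ring, would shift the number in opposite directions on the two cores, as phenyl does. Also open, on these data alone, is how the change behaves on a core that differs from the core of compound 1 in one place only, which would show where the reversal arises.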